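A few compounds are considered here, and "the series" means these few. Any claim that something is new, unique, unknown or untested is made for them only; others in the source may bear on it.

Two compounds share one core and differ only in the group attached to an amine nitrogen. Compound 1 `CC1=NN(C(=O)c2cc3ccccc3oc2=O)C(=O)C1CNc1ccccn1` carries pyridin-2-yl there; in a functional assay on the whole organism for inhibition, with Rattus norvegicus as the target, read by paw edema, with stated times of 1 h and 4 h, at a dose of 0.03 mg/kg by the oral route (a higher number here means more inhibition at the dose given (going by the name of the read-out), a lower number less inhibition), compound 1 gives 31.1%. Compound 2 `CC1=NN(C(=O)c2cc3ccccc3oc2=O)C(=O)C1CNc1cccc(S(N)(=O)=O)c1` carries 3-sulfamoylphenyl instead, and in this assay compound 2 gives 67.8%, the higher of the two numbers measured. Within the data shown here, the one step measured so far is a number 36.7 percentage points higher from compound 1 to compound 2 (beyond the scatter). Compound 3 `CC1=NN(C(=O)c2cc3ccccc3oc2=O)C(=O)C1CNc1ccc(S(N)(=O)=O)cc1` has not yet been measured; it differs from compound 2 by 4-sulfamoylphenyl in place of 3-sulfamoylphenyl on an amine nitrogen. Among the measured compounds shown here, no measured step compares 3-sulfamoylphenyl with 4-sulfamoylphenyl, so the step from compound 1 to compound 2, which exchanged one whole ring for a different one, bears on this change only loosely: it shows that a sulfamoylphenyl group on this nitrogen goes with a high number, and compound 3 keeps such a group. A step of no size beyond the scatter is therefore expected in this assay, and compound 3 is estimated at 64%, with a range from 44% to 84%. That estimate means an expected step of a number 3.8 percentage points lower from compound 2 to compound 3 (within the scatter).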

Compound 3, a percentage reported as inhibition, in the whole organism at one dose (the size of the read-out at that dose, not a potency): 68.9%
For compound 3 the middle estimate is 4.9 percentage points below the measured one; measured number inside the range.
By their numbers in this assay, from the lowest: compound 1; then compounds 2 and 3 (each within the scatter of the next).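

In this assay the exchange of 3-sulfamoylphenyl for 4-sulfamoylphenyl on the amine nitrogen gives a number 1.1 percentage points higher from compound 2 to compound 3 (within the scatter) and so these two groups, made of the same atoms joined differently, cannot be told apart at this dose. The exchange of pyridin-2-yl for 4-sulfamoylphenyl gives a number 37.8 percentage points higher from compound 1 to compound 3 (beyond the scatter) and this shows that the high number seen with compound 2 is not tied to 3-sulfamoylphenyl alone, since both sulfamoylphenyl groups shown on this nitrogen give more inhibition than pyridin-2-yl. Nothing at hand explains why these groups differ from pyridin-2-yl or why they match each other.

The compounds shown leave open whether the sulfamoyl group itself matters or the benzene ring alone is enough, a question that a plain phenyl group or a carboxyphenyl group on the same nitrogen could help to answer. They also leave open whether compound 2 and compound 3 would stay level at other oral doses, since a reading at a single dose is a size of effect and not a potency.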